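Tetrazolyl for triazolyl on the thioether sulfur

The compounds below may be only part of what the source reports. "The series", "measured", "known", "first", "only" and "open" are said of these compounds alone.

Of the compounds shown here, two carry numbers so far. Compound 1 `O=C(CSc1nnnn1-c1ccccc1)N/N=c1/scc(-c2ccc(F)cc2)n1-c1ccccc1` gives 24.3 ug/mL in a functional assay on C6 cells (Rattus norvegicus) for cytotoxicity, read by MTT assay, with a stated time of 24 h; on this read-out lower numbers stand for stronger inhibition and higher numbers for weaker inhibition. Compound 2 `Cn1cnnc1SCC(=O)N/N=c1/scc(-c2ccccc2)n1-c1ccccc1` gives 68.3 ug/mL in this assay, which is the highest of the two numbers; its nearest neighbour is compound 1, and the gap between the two lies beyond the usual scatter. Among the measured compounds shown here, no pair of measured compounds isolates a single structural change, so nothing is yet known about how one group trades against another.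

Compound 3 `O=C(CSc1nnnn1-c1ccccc1)N/N=c1/scc(-c2ccccc2)n1-c1ccccc1` is not yet measured. Against compound 2 the change is 1-phenyl-1H-tetrazol-5-yl in place of 4-methyl-4H-1,2,4-triazol-3-yl on a sulfur. For the measured compounds named here, the only pointer is compound 1, which also carries the 1-phenyl-1H-tetrazol-5-yl group on a sulfur and gives 24.3 ug/mL, the lower of the two numbers. On that basis the step from compound 2 is expected to go toward lower numbers and to exceed the scatter, as a 2.1-fold lower number from compound 2 to compound 3 (0.32 log units; beyond the scatter). The estimate for compound 3 is 33 ug/mL, with a range from 17 ug/mL to 65 ug/mL.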

Compound 3, half-maximal inhibitory concentration: 8.3 ug/mL
Beside the measured number, compound 3's estimate is 4.0-fold (0.60 log units) above it; the whole stated range lies above it.
By their numbers in this assay, from the lowest: compound 3; then compound 1; then compound 2.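

In this assay, the exchange of 4-methyl-4H-1,2,4-triazol-3-yl for 1-phenyl-1H-tetrazol-5-yl on a sulfur now has its first single-place reading (an 8.2-fold lower number from compound 2 to compound 3 (0.92 log units; beyond the scatter)), and it shows that this position on the saturated chain side of the sulfur moves the number well beyond the scatter with the rest of the molecule unchanged. The second step (a 2.9-fold lower number from compound 1 to compound 3 (0.47 log units; beyond the scatter)), hydrogen in place of fluoro on an aromatic carbon, shows that with 1-phenyl-1H-tetrazol-5-yl on the sulfur the fluoro is not needed for a low number, and that the number is lower without it. Nothing measured here accounts for the direction or the size of either step.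

The exchange on the sulfur changes both the five-membered ring and the added phenyl ring at once, so the compounds shown do not separate the two; 1-methyl-1H-tetrazol-5-yl or 4-phenyl-4H-1,2,4-triazol-3-yl on the same sulfur would do so. Also open, from the compounds shown here alone, is how chloro or methoxy would compare with hydrogen and fluoro on that aromatic carbon, and whether the fluoro step reads the same with 4-methyl-4H-1,2,4-triazol-3-yl on the sulfur.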